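This account rests on a few compounds, and the source may have more. Where it says the series, first, only, none or still open, it means among the compounds named here.

Measured so far in a functional assay on HUVEC cells (Homo sapiens) for inhibition, with stated times of 2 h and 72 h; a higher number here means a weaker inhibitor, a lower number a stronger inhibitor:
- Compound 1 `COc1cc2nccc(Oc3ccc4c(NC(=O)c5cc(C(F)(F)F)cc(C(F)(F)F)c5)nn(C)c4c3)c2cc1OC`: > 1000 nM, a limit
- Compound 2 `COc1cc2nccc(Oc3ccc4c(NC(=O)C5CC5)nn(C)c4c3)c2cc1OC`: > 1000 nM, a limit
- Compound 3 `COc1cc2nccc(Oc3ccc4c(NC(=O)c5cc(Cl)ccn5)nn(C)c4c3)c2cc1OC`: > 1000 nM, a limit

None of these three results is an exact number. Compound 2 therefore has no precise place on the scale, and it shares its position with the other two: the limit of > 1000 nM in this assay, at which 3 of the 3 values shown sit.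

Compound 4 `COc1ccc(C(=O)Nc2nn(C)c3cc(Oc4ccnc5cc(OC)c(OC)cc45)ccc23)cc1` keeps the core of compound 2 and changes one group, with 4-methoxyphenyl in place of cyclopropyl on a carbonyl carbon. Within the data shown here, the one measured step at this same place is a step that the two limits leave unreadable from compound 2 to compound 3. Both ends of that step are limits, so it offers no size to carry over to the new group, and it gives no direction either.

The expectation therefore rests only on the shared limit, and no clear gain in strength is expected from this change. The expected outcome is a step that the limit leaves unreadable from compound 2 to compound 4, a rough estimate that could well turn out to be another limit. For compound 4 the estimated value in this assay is 2000 nM, with an expected range of 400 nM to 10000 nM.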

Compound 4, half-maximal inhibitory concentration: > 1000 nM
Compound 4 was reported as a limit; the forecaster's own chance of this, stated with the estimate: 80%; the middle value is on the limit's open side.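

In this assay compound 4 gives > 1000 nM, which is a limit and not a number. Its steps from compound 2 and from compound 3 therefore cannot be read, and all four compounds share one position: the limit of > 1000 nM in this assay, at which 4 of the 4 values shown sit.

The compounds shown leave open how strongly any of them inhibits, and whether changing the group on the carbonyl carbon alters that strength.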